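The source may hold more compounds than are shown below. What is called first, only, known or untested is meant among the compounds shown, and "the series" means these compounds.

Two compounds share a core that carries a carbonyl-linked aryl group on an amide-type nitrogen, and both have been read in an assay (strain Wistar) for displacement of a labelled ligand from adenosine receptor A1 (Rattus norvegicus), read by scintillation counting; on this read-out higher numbers stand for weaker inhibition and lower numbers for stronger inhibition. Compound 1 `COc1ccc(Cl)cc1C(=O)Nc1nc(-c2ccccc2)nc2c1nnn2Cc1ccccc1` gives 7150 nM in this assay. Going by the values given here, compound 2 `Cc1ccc(C(=O)Nc2nc(-c3ccccc3)nc3c2nnn3Cc2ccccc2)cc1` gives 709 nM in this assay, the lowest of the two numbers; the only measured step, a 10-fold lower number from compound 1 to compound 2 (1.00 log units; beyond the scatter), arises from 4-methylphenyl in place of 5-chloro-2-methoxyphenyl on the carbonyl carbon. Compound 3 `O=C(Nc1nc(-c2ccccc2)nc2c1nnn2Cc1ccccc1)c1cccc(F)c1` remains to be measured in this assay. The change from compound 2 to compound 3 is 3-fluorophenyl in place of 4-methylphenyl on a carbonyl carbon. Among the compounds with values here, the one measured step bears on it only in kind: it shows that the substitution pattern of the aryl group on the carbonyl carbon can move this assay by a modest amount, but it gives no direct guide to a 3-fluorophenyl. The expectation is therefore a step of a 1.7-fold higher number from compound 2 to compound 3 (0.23 log units; within the scatter), a small weakening that may well fall within the scatter. Compound 3 is thus estimated at 1200 nM, with a range from 400 nM to 4000 nM.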

Compound 3, inhibition constant: 22 nM
The estimate for compound 3 lay 55-fold (1.74 log units) above the measured number; the whole stated range lies above it.
By their numbers in this assay, from the lowest: compound 3; then compound 2; then compound 1.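

In this assay the change to 3-fluorophenyl in place of 4-methylphenyl on the carbonyl carbon brings a 32-fold lower number from compound 2 to compound 3 (1.51 log units; beyond the scatter) and so shows that this position can respond strongly to one aryl group being swapped for another, not only by a modest amount. Both groups count 7 heavy atoms and one six-membered aromatic ring of carbon only, with no hydrogen-bond donors or acceptors, so this large step comes with no change in any of those counts. Against the 5-chloro-2-methoxyphenyl group, the 3-fluorophenyl group gives a 330-fold lower number from compound 1 to compound 3 (2.51 log units; beyond the scatter) and leaves compound 3 with the lowest number of the three, but no measurement at hand explains a step of this size.

The compounds shown leave open whether the drop in the number belongs to the fluorine itself or to the numbered place it holds on the ring, as the 4-methylphenyl and 3-fluorophenyl groups differ in both at once. An unsubstituted phenyl, 3-methylphenyl and 4-fluorophenyl on the same carbonyl carbon would pull those two apart, and 3-chlorophenyl would show whether another halogen follows fluorine.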